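Lengthening the alkylamine chain: cytotoxicity notes on a pyrazinamide set

A few compounds are considered here, and "the series" means these few. Any claim that something is new, unique, unknown or untested is made for them only; others in the source may bear on it.

Measured compounds:
- `O=C(NCc1ccccc1)c1cncc(Cl)n1` (compound 1): "not determined" (no result reported)
- `CCCCNc1nccnc1C(=O)NCc1ccccc1` (compound 2): > 100000 nM
- `CCCCCNc1cnc(C(=O)NCc2ccccc2)cn1` (compound 3): > 100000 nM

Three compounds share the benzylamide on an aromatic core. Compound 1, `O=C(NCc1ccccc1)c1cncc(Cl)n1`, carries a chlorine and has as its cytotoxicity result "not determined" (no result reported). In an ADME assay on HeLa cells (Homo sapiens) for cytotoxicity, read by microscopy, with a stated time of 6 days (on this read-out higher numbers stand for lower toxicity in this test and lower numbers for higher toxicity in this test), compound 2 gives > 100000 nM, which is a limit of the test rather than a number. Compound 3 likewise gives > 100000 nM, again a limit. So compound 2 stands where every reported value in this assay stands: at the limit, (the limit of > 100000 nM in this assay, at which 2 of the 3 values shown sit), with no single number anywhere in the set to rank it against.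

Compound 4, `CCCCCCCNc1nccnc1C(=O)NCc1ccccc1`, is the next member to be measured. It differs from compound 2 as propyl in place of hydrogen on a saturated chain carbon, four bonds along the chain from a nitrogen on an aromatic ring.

For the measured compounds named here, no step between measured compounds exists in this assay, so only an expectation can be stated. The step from compound 2 to compound 4 is expected to be a number no higher from compound 2 to compound 4 (the limit leaves the size open), that is, no change beyond the scatter, with the result most likely another limit. On that basis compound 4 is estimated at 100000 nM, within 30000 nM to 300000 nM.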

Compound 4, minimum cytotoxic concentration: > 100000 nM
Compound 4: only a limit was reported (the forecaster's own chance of this, stated with the estimate: 65%); the middle value sits exactly at the limit.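

Compound 4 stays at a limit, as compound 2 does, so no step can be read between compound 2 and compound 4: the limit of > 100000 nM in this assay, at which 3 of the 4 values shown sit.

Whether any chain on the shared core gives a single number in this assay is left open by the compounds shown.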